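The source may hold more compounds than are shown below. What is called first, only, known or untested is meant among the compounds shown, and "the series" means these compounds.

Series notes. Compound 1 `Cn1cc(-c2nc3ccccc3n2C(=O)c2ccccc2)c2ccccc21` is the starting point; in a functional assay on HepG2 cells (Homo sapiens) for inhibition, read by MTT assay, with a stated time of 24 h (a lower number here means a stronger inhibitor of growth, a higher number a weaker inhibitor of growth), compound 1 gives 42300 nM. Compound 2 `COc1ccc(C(=O)n2c(-c3cn(C)c4ccccc34)nc3ccccc32)cc1` carries the change (methoxy in place of hydrogen on an aromatic carbon), and in this assay compound 2 gives 15200 nM; the step of a 2.8-fold lower number from compound 1 to compound 2 (0.44 log units; beyond the scatter) lies beyond the scatter. Compound 3 `COc1ccc2c(c1)c(-c1nc3ccccc3n1C(=O)c1ccc(OC)c(OC)c1)cn2C` rests on a core that differs from the core of compound 1 in more than one place; the difference between the two cores is not broken down here. In this assay compound 3 gives 5100 nM, the lowest of the three numbers, with its steps to compound 2 and to compound 1 both beyond the scatter.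

Compound 4 `COc1ccc2c(c1)c(-c1nc3ccccc3n1C(=O)c1cc(OC)c(OC)c(OC)c1)cn2C` is not yet measured. It differs from compound 3 by methoxy in place of hydrogen on an aromatic carbon. For the measured compounds named here, this is the same kind of change as the one from compound 1 to compound 2, but not the same: in compound 2 the entering methoxy sits para to a large group, whereas in compound 4 it sits ortho to a methoxy group, meta to a large group and meta to a methoxy group.

Expectation: with the one measured instance of this change, a 2.8-fold lower number from compound 1 to compound 2 (0.44 log units; beyond the scatter), as the only guide, compound 4 is expected to give about 3000 nM in this assay, with a range from 1200 nM to 8000 nM. The expected step of a 1.7-fold lower number from compound 3 to compound 4 (0.23 log units; within the scatter) is set below the measured 2.8-fold lower number from compound 1 to compound 2 (0.44 log units; beyond the scatter): a single instance and a different placement of the entering methoxy give thin support for a full repeat.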

Compound 4, concentration for 50% growth inhibition: 3800 nM
Compound 4: middle estimate off by 1.3-fold (0.10 log units), on the low side, within the range that was stated.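

In this assay the added methoxy gives a 1.3-fold lower number from compound 3 to compound 4 (0.13 log units; within the scatter), a step that stays within the scatter, so on the core of compound 3 this change has no effect that can be separated from repeat variation. Set beside the earlier step, the two instances of the change cannot be told apart: the same change on two cores in this assay, a 2.8-fold lower number (0.44 log units; beyond the scatter) from compound 1 to compound 2 and a 1.3-fold lower number (0.13 log units; within the scatter) from compound 3 to compound 4, 2.1-fold (0.32 log units) apart, within the scatter of two such steps

For the compounds shown here, this agreement shows that the data are compatible with the change carrying from one core to the other, but it does not show a transferable step of fixed size, since only one of the two steps lies beyond the scatter, the cores differ in more than one place and the entering methoxy does not stand in the same place on both, so two instances cannot separate any influence of core from one of placement.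

The compounds shown leave open whether a different group on the same aromatic carbon, such as an amine, a carboxylic acid or a longer chain in place of methoxy, would give a step beyond the scatter on the core of compound 3. They also leave open how the same methoxy would behave in the same placement on the core of compound 1.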